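Replacing ((furan-2-yl)carbonyl)oxy with acetamido on the saturated ring

The source may hold more compounds than are shown below. What is called first, only, known or untested is meant among the compounds shown, and "the series" means these compounds.

In an ADME assay on cells (Hepatocyte, Mus musculus) for metabolic stability, with a stated time of 30 min (on this read-out lower numbers stand for a less stable compound and higher numbers for a more stable compound), the three measured compounds read as follows
compound 1 `O=C(OC1CCC(CN2CCN(c3cc(=O)c4cc(C(F)(F)F)cc([N+](=O)[O-])c4s3)CC2)CC1)c1ccncc1` gives 1.4%
compound 2 `Cc1ccc(C(=O)OC2CCC(CN3CCN(c4cc(=O)c5cc(C(F)(F)F)cc([N+](=O)[O-])c5s4)CC3)CC2)cc1` gives 18%
compound 3 `O=C(OC1CCC(CN2CCN(c3cc(=O)c4cc(C(F)(F)F)cc([N+](=O)[O-])c4s3)CC2)CC1)c1ccco1` gives 0.6%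

Compound 3 and compound 1 cannot be told apart within the scatter, and both lie clearly under compound 2. Compound 4 `CC(=O)NC1CCC(CN2CCN(c3cc(=O)c4cc(C(F)(F)F)cc([N+](=O)[O-])c4s3)CC2)CC1` has acetamido in place of ((furan-2-yl)carbonyl)oxy on a saturated ring carbon and is otherwise the same.

The closest evidence comes from swaps of the group on the carbonyl carbon. One stayed within the scatter (a number 0.8 percentage points lower from compound 1 to compound 3 (within the scatter)). Two were modest and beyond it (a number 16.6 percentage points higher from compound 1 to compound 2 (beyond the scatter) and a number 17.4 percentage points lower from compound 2 to compound 3 (beyond the scatter)). None of these steps removes the whole group as compound 4 does, so they are only a loose guide to its size. Compound 3 at 0.6% has little room to fall, so a modest rise is expected. The estimated step is modest and uncertain (a number 17.4 percentage points higher from compound 3 to compound 4 (beyond the scatter)). In this assay compound 4 is estimated at 18% with an expected range (3% to 50%).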

Compound 4, percent of the compound remaining: 94.9%
For compound 4 the middle estimate is 76.9 percentage points below the measured one; measured number above the stated range.
By their numbers in this assay, from the lowest: compounds 3 and 1 (each within the scatter of the next); then compound 2; then compound 4.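

In this assay, acetamido on the saturated ring carbon gives a far higher number than each of the three carbonyloxy groups it replaces (a number 94.3 percentage points higher from compound 3 to compound 4 (beyond the scatter)) and (a number 93.5 percentage points higher from compound 1 to compound 4 (beyond the scatter)) and (a number 76.9 percentage points higher from compound 2 to compound 4 (beyond the scatter)). The largest earlier swap, which changed only the group on the carbonyl carbon, was much smaller (a number 17.4 percentage points lower from compound 2 to compound 3 (beyond the scatter)), so replacing the whole group at this position moves the number far more than any swap among those carbonyl substituents did. No measurement shown explains why the number rises so far.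

As far as these compounds go, it remains open whether the nitrogen link or the short acetyl end accounts for the rise: a benzamido group or a plain amine on the same ring carbon would help separate the two. Stability is also the only read-out shown, so the effect of this change on any other measure is unknown.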